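Methyl on selenium: from compound 3 to compound 4

This account rests on a few compounds, and the source may have more. Where it says the series, first, only, none or still open, it means among the compounds named here.

Compound 3 `[SeH]c1nc(NCc2ccccc2)c2ccccc2n1` is the parent of this step. In a functional assay on MCF7 cells (Homo sapiens) for cytotoxicity, read by MTT assay, with a stated time of 72 h (a lower number here means that less compound is tolerated, a higher number that more compound is tolerated), compound 3 gives > 100000 nM, which is a limit of the assay and not a number. Compound 2 `Sc1nc(NCc2ccccc2)c2ccccc2n1` also sits at a limit; in this assay compound 2 gives > 100000 nM. Compound 1 `COc1ccc(CNc2nc([Se]C)nc3ccccc23)cc1` does the same; in this assay compound 1 gives > 100000 nM. For the measured compounds named here, all three values so far rest at the limit of > 100000 nM in this assay, at which 3 of the 3 values shown sit, so compound 3 stands nowhere distinguishable from the other two. Going by the values given here, the only step among measured neighbours, a step that the two limits leave unreadable from compound 2 to compound 3, is left unreadable by the two limits.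

Compound 4 `C[Se]c1nc(NCc2ccccc2)c2ccccc2n1` differs from compound 3 by methyl in place of hydrogen on a selenium. Among the compounds with values here, no measured step bears directly on this change. Compound 1, which already carries a methyl on selenium, gives only > 100000 nM in this assay, which is the nearest hint. For compound 4 in this assay the expected value is 120000 nM, with a range from 40000 nM to 400000 nM. The expected step that the limit leaves unreadable from compound 3 to compound 4 is therefore none beyond the scatter, most likely ending again at the limit.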

Compound 4, concentration lethal to 50% of the cells: > 100000 nM
Compound 4: no number, only a limit; the forecaster's own chance of this, stated with the estimate: 80%; the middle value is on the limit's open side.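

Compound 4 gives > 100000 nM as a limit and not a number. For the compounds shown here, no step among compound 1, compound 2, compound 3 and compound 4 can be read: the limit of > 100000 nM in this assay, at which 4 of the 4 values shown sit.

The compounds shown leave open which change to the shared core, if any, would give a readable value.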